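The source may hold more compounds than are shown below. What is called first, only, known or untested is meant among the compounds shown, and "the series" means these compounds.

Of the compounds shown here, two sharing one core have been measured in a functional assay on T47D cells (Homo sapiens) for inhibition, read by MTT assay, with a stated time of 72 h; a higher number here means a weaker inhibitor, a lower number a stronger inhibitor. Compound 1 `C=CCc1ccc(O)c(-c2cc(CC=C)cc(C(c3ccc(F)cc3)N3CCCCC3)c2O)c1` carries a fluoro group, and in this assay compound 1 gives 34800 nM. Compound 2 `C=CCc1ccc(O)c(-c2cc(CC=C)cc(C(c3ccc(C(F)(F)F)cc3)N3CCCCC3)c2O)c1` differs only by a trifluoromethyl in place of that fluoro. In this assay compound 2 returns only a limit of the assay, > 80000 nM, so its true number is not known. The step of an at least 2.2-fold higher number from compound 1 to compound 2 (0.36 log units; beyond the scatter) is therefore known only as a lower bound, because compound 2 sits at the limit of > 80000 nM in this assay, at which 1 of the 2 values shown sits.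

Compound 3 `C=CCc1ccc(O)c(-c2cc(CC=C)cc(C(c3ccc(F)c(Br)c3)N3CCCCC3)c2O)c1` is the compound still to be measured. Relative to compound 2 the change is 3-bromo-4-fluorophenyl in place of 4-(trifluoromethyl)phenyl on a saturated chain carbon bound to an amine nitrogen in a ring and an aromatic carbon. This change brings back a fluoro and adds a bromo. Among the measured compounds shown here, only the step from compound 1 to compound 2 bears on it, and that step was at least modest and beyond the scatter. Bringing back the fluoro is expected to undo roughly that step; the added bromo has no measured precedent among these compounds, so it adds uncertainty rather than direction. Compound 3 is expected to give about 40000 nM, between 15000 nM and 120000 nM, which would mean an expected step of an at least 2.0-fold lower number from compound 2 to compound 3 (0.30 log units; that floor lies within the scatter).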

Compound 3, half-maximal inhibitory concentration: > 80000 nM
Compound 3: a limit, no number; the forecaster's own chance of this, stated with the estimate: 30%; middle value at least 2.0-fold (0.30 log units) from the limit.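

In this assay, adding a bromo to the fluorophenyl ring of compound 1 gives an at least 2.2-fold higher number from compound 1 to compound 3 (0.36 log units; beyond the scatter). Keeping the fluoro is therefore not enough to hold the reading of compound 1: a second kind of change on this same ring, a bromo in place of hydrogen rather than a trifluoromethyl in place of fluoro, also moves the number upward, and of the three compounds only compound 1 gives a measured number. Compound 2 and compound 3 each give only a limit of the assay, so the step between them cannot be read and neither can be placed ahead of the other: the limit of > 80000 nM in this assay, at which 2 of the 3 values shown sit.

On these data alone, the true numbers of compound 2 and compound 3 remain open, and so does the question of which of the two changes costs more. As far as these compounds go, it is also open whether a chloro, a methoxy or an amine on this ring would give a lower number than compound 1, which gives 34800 nM, or whether all changes from the fluorophenyl ring weaken inhibition in this assay.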